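Methoxy in Place of Ethoxy on a Non-cytotoxic Carbamate

A few compounds are considered here, and "the series" means these few. Any claim that something is new, unique, unknown or untested is made for them only; others in the source may bear on it.

Compound 3 `CCOCCOC(=O)Nc1cc2nc(C3CCCCC3)[nH]c2cc1N1CCCC1` stands at the top of the range that the assay can report. In an ADME assay on Vero cells (Chlorocebus sabaeus) for cytotoxicity, read by resazurin assay, with a stated time of 3 days (on this read-out higher numbers stand for weaker inhibition and lower numbers for stronger inhibition), compound 3 gives > 100 ug/mL, and this is a limit of the assay rather than a number. The two neighbours share that position. Compound 1 `CCCCCC(=O)Nc1cc2nc(C3CCCCC3)[nH]c2cc1N1CCCC1` gives > 100 ug/mL in this assay, again a limit. Compound 2 `CCCOCC(=O)Nc1cc2nc(C3CCCCC3)[nH]c2cc1N1CCCC1` gives > 100 ug/mL in this assay, also a limit. Because of the limit of > 100 ug/mL in this assay, at which 3 of the 3 values shown sit, none of the steps between them can be sized: the step that the two limits leave unreadable from compound 1 to compound 2, the step that the two limits leave unreadable from compound 1 to compound 3 and the step that the two limits leave unreadable from compound 2 to compound 3 all remain unreadable, and nothing in this set separates one compound from another in cytotoxicity.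

Compound 4 `COCCOC(=O)Nc1cc2nc(C3CCCCC3)[nH]c2cc1N1CCCC1` differs from compound 3 by hydrogen in place of methyl on a saturated chain carbon bound to an oxygen on a saturated carbon. Among the measured compounds shown here, the steps that bear on it are the three just named, and each of them shows no measurable size, so the change from compound 3 to compound 4 is expected to show no step beyond the scatter, with a step that the limit leaves unreadable from compound 3 to compound 4 as the estimated size. Compound 4 is therefore expected to give about 150 ug/mL in this assay, within a range from 60 ug/mL to 400 ug/mL, most likely reported again only as a limit.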

Compound 4, half-maximal inhibitory concentration: > 100 ug/mL
Compound 4 ended at the assay's limit; the forecaster's own chance of this, stated with the estimate: 90%; the middle value is on the limit's open side.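

The steps from compound 1, compound 2 and compound 3 to compound 4 cannot be read in this assay, because all four compounds share one limit: the limit of > 100 ug/mL in this assay, at which 4 of the 4 values shown sit.

The compounds shown leave open whether any one of the four differs from another in cytotoxicity, and at what concentration any of them would reach half-maximal inhibition.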